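The source may hold more compounds than are shown below. What is called first, only, known or untested is meant among the compounds shown, and "the series" means these compounds.

Measured in a functional assay on Jurkat cells (Homo sapiens) for cytotoxicity, with a stated time of 72 h; a lower number here means that less compound is needed, a higher number that more compound is needed for the effect:
- compound 1 `C=C[C@@](C)(/C=C/c1ccc(O)cc1)CC/C=C(\C)C(=O)OCC`: > 49000 nM
- compound 2 `C=C[C@@](C)(/C=C/c1ccc(O)c(C=O)c1)CCC=C(C)C`: > 49000 nM
- compound 3 `C=C[C@@](C)(/C=C/c1ccc(O)c(/C=C/C(=O)NCc2ccc(C(F)(F)F)cc2)c1)CCC=C(C)C`: > 49000 nM

The ">" sign marks each of these entries as a limit of the assay and not a true number. Compound 2 gives only such a limit, > 49000 nM. The other two compounds offer no number to compare it with, as the whole set shows (the limit of > 49000 nM in this assay, at which 3 of the 3 values shown sit).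

The next compound to be tested is compound 4 `C=C[C@@](C)(/C=C/c1ccc(O)c(/C=C(\C)C(=O)OCC)c1)CCC=C(C)C`. It differs from compound 2 at one place: 2-(ethoxycarbonyl)prop-1-en-1-yl in place of formyl on an aromatic carbon. In words, a 2-(ethoxycarbonyl)prop-1-en-1-yl group stands in place of formyl on an aromatic carbon, ortho to a hydroxy group.

With compound 1, compound 2 and compound 3 all resting at the limit of > 49000 nM in this assay, at which 3 of the 3 values shown sit, no change beyond the usual scatter is expected in either direction, and another limit is quite possible. The expected size of the change is a number no higher from compound 2 to compound 4 (the limit leaves the size open). The estimate for compound 4 is 49000 nM, with an expected range from 20000 nM to 80000 nM.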

Compound 4, half-maximal effective concentration: > 49000 nM
Compound 4 gave a limit, no number (the forecaster's own chance of this, stated with the estimate: 70%); the middle value sits exactly at the limit.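

Compound 4 gives > 49000 nM in this assay, which is a limit of the assay and not a number. Among these compounds, compound 2 also gives only a limit, so no step from compound 2 to compound 4 can be read. The compounds shown leave open what true value any of them has: the limit of > 49000 nM in this assay, at which 4 of the 4 values shown sit.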